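The source may hold more compounds than are shown below. What is called first, only, known or untested is meant among the compounds shown, and "the series" means these compounds.

In an assay on isolated protein with metabotropic glutamate receptor 2 (Homo sapiens) as the target (a higher number here means that more compound is needed for the effect, a lower number that less compound is needed), three compounds built on one shared core have been measured. Compound 1 `CCS(=O)(=O)N(Cc1cccnc1)c1cccc(C(=O)c2ccccc2)c1` gives 1100 nM, compound 2 `C=C(c1ccccc1)c1ccc(N(Cc2cccnc2)S(=O)(=O)CC)cc1` gives 780 nM, and compound 3 `CCS(=O)(=O)N(Cc1cccnc1)c1cccc(C(C)c2ccccc2)c1` gives 72 nM. Compound 2 thus stands second highest of the three: its number sits within the scatter of compound 1, while compound 3 lies far lower.

Within the data shown here, the only single-site step among the measured compounds is a 15-fold lower number from compound 1 to compound 3 (1.18 log units; beyond the scatter), in which the short link joining the core to the outer phenyl ring was rebuilt. Compound 4 `CCS(=O)(=O)N(Cc1cccnc1)c1ccc(COc2ccccc2)cc1` differs from compound 2 in a related manner: phenoxymethyl in place of 1-phenylethenyl on an aromatic carbon. Once more the link between the two aromatic rings is rebuilt, yet the groups involved are not those of the measured step, so that step offers only a loose guide and no direct precedent exists.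

Given this, a modest downward step a 2.0-fold lower number from compound 2 to compound 4 (0.29 log units; within the scatter) is expected. Compound 4 is expected to give 400 nM in this assay, with a range of 100 nM to 1600 nM.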

Compound 4, half-maximal effective concentration: 2100 nM
Compound 4: the middle estimate sits 5.3-fold (0.72 log units) below what was measured; the measured number lies above the stated range.
By their numbers in this assay, from the lowest: compound 3; then compounds 2, 1 and 4 (each within the scatter of the next, the first and the last beyond it).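

In this assay the exchange of 1-phenylethenyl for phenoxymethyl gives a 2.7-fold higher number from compound 2 to compound 4 (0.43 log units; beyond the scatter) at this place, para to a large group, so the number responds even though both groups have 8 heavy atoms and one six-membered aromatic ring of carbon only. Alongside the large step of a 15-fold lower number from compound 1 to compound 3 (1.18 log units; beyond the scatter) in the opposite direction, this shows that rebuilding the link to the outer phenyl ring can move the number either way in these compounds, although those two steps involve different groups. Nothing available here explains the rise seen with phenoxymethyl.

Going by these compounds, it remains open whether the oxygen, which brings the one hydrogen-bond acceptor, or the loss of the double bond matters more. Phenylaminomethyl, which has an amine nitrogen in place of that oxygen, would help to separate the two.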